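This account rests on a few compounds, and the source may have more. Where it says the series, first, only, none or still open, it means among the compounds named here.

Compounds measured in a functional assay on isolated protein with Glucose-dependent insulinotropic receptor (Mus musculus) as the target, read by HTRF and cAMP accumulation, with a stated time of 45 min; a lower number here means a smaller maximal response, a higher number a larger maximal response:
- compound 1, `C[C@@H]1CN(C(=O)OC(C)(C)C)CCN1c1ncc(OCc2ccc(C#N)cc2)cn1`: 88%
- compound 2, `C[C@@H]1CN(C(=O)OC(C)(C)C)CCN1c1ncc(OCc2ccc(-n3cnnn3)cc2)cn1`: 115%
- compound 3, `C[C@@H]1CN(C(=O)OC(C)(C)C)CCN1c1ncc(OCc2ccc(S(C)(=O)=O)cc2F)cn1`: 90%

Compound 3 stands second highest of the three numbers in this assay. Its nearest neighbour is compound 1, and the pair differ only a number 2 percentage points higher from compound 1 to compound 3 (within the scatter). Compound 2 lies furthest away, as shown by a number 25 percentage points lower from compound 2 to compound 3 (beyond the scatter), while compound 2 itself stands apart from compound 1 by a number 27 percentage points higher from compound 1 to compound 2 (beyond the scatter).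

Compound 4, `C[C@@H]1CN(C(=O)OC(C)(C)C)CCN1c1ncc(OCc2ccc(S(C)(=O)=O)cc2C#N)cn1`, differs from compound 3 by cyano in place of fluoro on an aromatic carbon. Among the measured compounds shown here, no measured step swaps these two groups at this place. For the measured compounds named here, the one step that kept the para substituent and touched the same ring, from compound 1 to compound 3, was within the scatter, whereas the two steps beyond the scatter both involved the tetrazolyl group of compound 2, which compound 4 does not carry. A small step is therefore expected in this assay, with no direction beyond the scatter.

Compound 4 is thus estimated at 90%, between 75% and 105%, meaning an expected step of no change at the digits printed from compound 3 to compound 4 (within the scatter).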

Compound 4, intrinsic activity: the largest response reached, in percent of the reference agonist's: 103%
Estimate against measurement, compound 4: 13 percentage points below; measured number inside the range.
By their numbers in this assay, from the lowest: compounds 1 and 3 (each within the scatter of the next); then compound 4; then compound 2.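

In this assay, the aromatic carbon ortho to a large group and meta to a methylsulfonyl group proves to matter: cyano in place of fluoro gives a number 13 percentage points higher from compound 3 to compound 4 (beyond the scatter) and thus a modest change beyond the scatter. The earlier step to this ring, a number 2 percentage points higher from compound 1 to compound 3 (within the scatter), altered more than one place at once, so it could not isolate this position, whereas here a single swap moves the maximal response. No measurement shown offers a reason for this rise.

On these data alone, what an amine, a methoxy group or a carboxylic acid would do on this aromatic carbon remains open. Also open, as far as these compounds go, is whether cyano in place of fluoro would give a similar step with a 1H-tetrazol-1-yl group instead of the methylsulfonyl group on the same ring.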